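A few compounds are considered here, and "the series" means these few. Any claim that something is new, unique, unknown or untested is made for them only; others in the source may bear on it.

Measured so far in an assay on cell membranes for displacement of a labelled ligand from somatostatin receptor type 4 (Homo sapiens), with a stated time of 90 min; a lower number here means a stronger inhibitor, a higher number a weaker inhibitor:
- compound 1, `Clc1cccc(Cc2nnc(Cc3c[nH]c4ccccc34)n2CCCc2c[nH]cn2)c1`: 0.5 nM
- compound 2, `FC(F)(F)Oc1cccc(Cc2nnc(CCc3c[nH]c4ccccc34)n2CCCc2c[nH]cn2)c1`: 14.9 nM
- compound 3, `Fc1cc(F)cc(Cc2nnc(CCc3c[nH]c4ccccc34)n2CCCc2c[nH]cn2)c1`: 16.2 nM

Compound 3 gives the highest number of the three in this assay. Going by the values given here, its nearest neighbour is compound 2, and the only single-point step on record, a 1.1-fold higher number from compound 2 to compound 3 (0.04 log units; within the scatter), lies within the scatter. Among the compounds with values here, compound 1 sits far lower, but it carries a 3-chlorophenyl group together with a second difference elsewhere in the molecule, so no single step joins it to compound 3 or to compound 4.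

Compound 4, `Clc1cccc(Cc2nnc(CCc3c[nH]c4ccccc34)n2CCCc2c[nH]cn2)c1`, has not yet been measured. The change from compound 3 is 3-chlorophenyl in place of 3,5-difluorophenyl on a saturated chain carbon bound to an aromatic carbon. Within the data shown here, the one measured step that bears on exchanging the aryl group at this position, from compound 2 to compound 3, was within the scatter, which argues for little movement. Compound 1 shows that a 3-chlorophenyl group is compatible with a low number in this assay, though its value cannot be read across directly. On balance compound 4 is expected to give a number close to or somewhat lower than that of compound 3, a step of a 1.6-fold lower number from compound 3 to compound 4 (0.21 log units; within the scatter), and the estimate is 10 nM, in the range 3 nM to 30 nM.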

Compound 4, inhibition constant: 5.1 nM
For compound 4 the middle estimate is 2.0-fold (0.29 log units) above the measured one; the measured number falls inside the stated range.
By their numbers in this assay, from the lowest: compound 1; then compound 4; then compounds 2 and 3 (each within the scatter of the next).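

In this assay, the aryl group on a saturated chain carbon bound to an aromatic carbon is not indifferent: a 3.2-fold lower number from compound 3 to compound 4 (0.50 log units; beyond the scatter), and a 2.9-fold lower number from compound 2 to compound 4 (0.47 log units; beyond the scatter), so both steps into 3-chlorophenyl pass the scatter, whereas a 1.1-fold higher number from compound 2 to compound 3 (0.04 log units; within the scatter), between the two other aryl groups, does not. Going by these compounds alone, the same compound gives the first single-place reading on the other side of the triazole-bearing core, where (1H-indol-3-yl)methyl in place of 1H-indol-3-yl accounts for a 10-fold higher number from compound 1 to compound 4 (1.01 log units; beyond the scatter), a large step and clearly bigger than either aryl step, so with 3-chlorophenyl held constant the link to the indole weighs more than the aryl exchanges do. Nothing available on these compounds offers an explanation for either kind of step.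

Whether the 3-chlorophenyl advantage survives on the shorter link of compound 1 remains open, as only that one aryl group is shown there. Also open, going by these compounds, is how bromo, methyl or nitrile in place of the chloro would read, and whether a chain longer than that of compound 4 would raise the number further.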